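The source may hold more compounds than are shown below. What is called first, only, known or untested is meant among the compounds shown, and "the series" means these compounds.

Compound 3 `O=C(NCc1cn(Cc2ccc(F)cc2)nn1)c1cn(-c2ccccc2)nc1-c1ccc(Cl)cc1` gives the lowest number of the three measured in a functional assay on MIA PaCa-2 cells (Homo sapiens) for antiproliferative activity, read by sulforhodamine B assay, with a stated time of 48 h (a lower number here means a stronger inhibitor of growth, a higher number a weaker inhibitor of growth), at 1990 nM. Compound 1 `O=C(NCc1cn(Cc2ccc(F)cc2)nn1)c1cn(-c2ccccc2)nc1-c1ccccc1` gives 9600 nM and compound 2 `O=C(NCc1cn(Cc2ccc(F)cc2)nn1)c1cn(-c2ccccc2)nc1-c1ccc(F)cc1` gives 14300 nM; accordingly a 4.8-fold lower number from compound 1 to compound 3 (0.68 log units; beyond the scatter) and a 7.2-fold lower number from compound 2 to compound 3 (0.86 log units; beyond the scatter), whereas a 1.5-fold higher number from compound 1 to compound 2 (0.17 log units; within the scatter). Compound 4 `COc1ccc(-c2nn(-c3ccccc3)cc2C(=O)NCc2cn(Cc3ccc(F)cc3)nn2)cc1` differs from compound 3 by methoxy in place of chloro on an aromatic carbon. For the measured compounds named here, no measured step replaces chloro with methoxy, so only the steps introducing chloro or fluoro bear on it: chloro brought a modest gain, fluoro nothing beyond the scatter. Because a 4.8-fold lower number from compound 1 to compound 3 (0.68 log units; beyond the scatter) rested on chloro alone, compound 4 is expected to give back part of that gain, with a 2.5-fold higher number from compound 3 to compound 4 (0.40 log units; beyond the scatter) expected. For compound 4 the estimate in this assay is 5000 nM, expected to lie between 1500 nM and 16000 nM.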

Compound 4, concentration for 50% growth inhibition: 24100 nM
Compound 4: middle estimate off by 4.8-fold (0.68 log units), on the low side; the measured number lies above the stated range.
By their numbers in this assay, from the lowest: compound 3; then compounds 1, 2 and 4 (each within the scatter of the next, the first and the last beyond it).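

In this assay methoxy at this place does not merely give back part of the gain seen with chloro: the change shows a 12-fold higher number from compound 3 to compound 4 (1.08 log units; beyond the scatter) and the comparison with hydrogen shows a 2.5-fold higher number from compound 1 to compound 4 (0.40 log units; beyond the scatter) as well. The comparison with fluoro shows a 1.7-fold higher number from compound 2 to compound 4 (0.23 log units; within the scatter) and leaves chloro the only group shown on this carbon that lowers the number. Nothing measured here explains this difference between chloro and methoxy. As far as these compounds go, whether bromo, methyl, trifluoromethyl or an amine at this place would follow chloro or methoxy remains open.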